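The source may hold more compounds than are shown below. What is called first, only, known or untested is meant among the compounds shown, and "the series" means these compounds.

Measured compounds:
Compound 1 `COc1cc(C(C)=O)ccc1OCCCN1CCC(C(c2ccc(C)cc2)c2ccc(C)cc2)CC1` in a functional assay (aorta) with Oryctolagus cuniculus as the target; a lower number here means tighter binding, a higher number weaker binding: 15.9 nM
Compound 2 `COc1cc(C(=O)O)ccc1OCCCN1CCC(C(c2ccc(F)cc2)c2ccc(F)cc2)CC1` in this assay: 79.4 nM

Of these two, compound 2 stands at the higher number in this assay; compound 1 sits a good way lower, and the gap between them is beyond the usual scatter. Among the measured compounds shown here, the two compounds differ in more than one place, so no single step between them is defined.

Compound 3 `COc1ccccc1OCCCN1CCC(C(c2ccc(F)cc2)c2ccc(F)cc2)CC1` is not yet measured. It differs from compound 2 in one place only: hydrogen in place of carboxy on an aromatic carbon. For the measured compounds named here, no measured pair shows this same change, so nothing here tells how large a step to expect; the expectation rests on compound 2 alone, with its value of 79.4 nM in this assay.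

For compound 3 a modest step toward a lower number is estimated in this assay, of size a 2.0-fold lower number from compound 2 to compound 3 (0.30 log units; within the scatter), and the estimate for compound 3 is 40 nM, within the range 10 nM to 160 nM.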

Compound 3, dissociation constant: 2.51 nM
Estimate against measurement, compound 3: 16-fold (1.20 log units) above; measured number below the stated range.
By their numbers in this assay, from the lowest: compound 3; then compound 1; then compound 2.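

Taking the carboxy off this aromatic carbon, meta to a methoxy group and para to a large group, gives a 32-fold lower number from compound 2 to compound 3 (1.50 log units; beyond the scatter) in this assay and this large step lies beyond the scatter. The earlier compounds shown here differ in more than one place and could not isolate this position; the pair now shows that the number at this carbon depends strongly on what sits there, with hydrogen giving the lower number and carboxy the higher. The data shown offer no measurement that would explain the size of this step.

The compounds shown leave open how other groups on this carbon, such as an amine, a hydroxy group or a methyl ester, would compare with hydrogen and carboxy. They also leave open whether the same change would give a step of similar size on a different core.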